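The compounds below may be only part of what the source reports. "The series", "measured", "known", "first", "only" and "open" are said of these compounds alone.

Compound 2 `O=C1O[C@H]([C@@H](O)Cn2cc(-c3cc(F)cc(F)c3)nn2)C(OCc2ccccc2)=C1OCc1ccccc1` belongs to a small set built on a shared core, in which a five-membered aromatic ring with 3 nitrogen carries a variable group. In a functional assay on HCT-116 cells (Homo sapiens) for antiproliferative activity, read by MTT assay, with a stated time of 72 h (a lower number here means a stronger inhibitor, a higher number a weaker inhibitor), compound 2 gives 48200 nM. Within the data shown here, the only other measured compound, compound 1 `O=C1O[C@H]([C@@H](O)Cn2cc(C3CC3)nn2)C(OCc2ccccc2)=C1OCc1ccccc1`, carries a cyclopropyl at that position and gives 30400 nM. The two numbers sit close together: a 1.6-fold higher number from compound 1 to compound 2 (0.20 log units; within the scatter), so compound 2 cannot be called stronger or weaker than compound 1 on these data.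

Compound 3 `O=C1O[C@H]([C@@H](O)Cn2cc(CCO)nn2)C(OCc2ccccc2)=C1OCc1ccccc1` has not yet been measured. It differs from compound 2 at the same position: 2-hydroxyethyl in place of 3,5-difluorophenyl on an aromatic carbon. Among the measured compounds shown here, the single measured step at this position, from cyclopropyl to 3,5-difluorophenyl, bears on it, and that step stayed within the scatter. The 2-hydroxyethyl is a short chain rather than a ring, but nothing measured tells whether that matters. The expected step is therefore a 1.4-fold lower number from compound 2 to compound 3 (0.14 log units; within the scatter) in this assay, essentially none beyond the scatter. Compound 3 is estimated at 35000 nM, within a range from 12000 nM to 100000 nM.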

Compound 3, half-maximal inhibitory concentration: 72700 nM
Estimate against measurement, compound 3: 2.1-fold (0.32 log units) below; the range from low to high includes it.
By their numbers in this assay, from the lowest: compounds 1, 2 and 3 (each within the scatter of the next, the first and the last beyond it).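

Among these compounds, putting 2-hydroxyethyl in place of cyclopropyl gives a 2.4-fold higher number from compound 1 to compound 3 (0.38 log units; beyond the scatter) in this assay, the first step at this position that goes beyond the scatter, though only modestly. Putting the same chain in place of 3,5-difluorophenyl gives a 1.5-fold higher number from compound 2 to compound 3 (0.18 log units; within the scatter), so on these data the chain can be told apart from cyclopropyl but not from 3,5-difluorophenyl, and swapping that six-membered aromatic ring for a short chain with a hydrogen-bond donor does not produce a clear change. No supporting measurement is available to explain these differences.

The compounds shown leave open whether the higher number for compound 3 compared with compound 1 goes with the hydroxyl or with the open chain, as the two groups differ in both respects. From the compounds shown here alone, it also remains unknown how a plain ethyl, a longer chain, or a chain ending in an amine or a carboxylic acid would read here, and whether any group at this position could bring the number well below that of compound 1.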